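Halogen Pattern Trimmed to a Single Chlorine

A few compounds are considered here, and "the series" means these few. Any claim that something is new, unique, unknown or untested is made for them only; others in the source may bear on it.

Compound 1 `Cn1c(Cc2nn(C)c(=O)c3ccccc23)nnc1SCCCCCCCC(=O)Nc1ccc(F)cc1F` gives 2300 nM in an assay on isolated protein (Mus musculus) for inhibition of IL15-IL15 receptor (Homo sapiens), read by resazurin assay, with stated times of 30 min and 2.5 days; on this read-out higher numbers stand for weaker inhibition and lower numbers for stronger inhibition.
Compound 2 `Cn1c(Cc2nn(C)c(=O)c3ccccc23)nnc1SCCCCCCCC(=O)Nc1ccc(Cl)cc1Cl` gives 1900 nM in this assay.
Compound 3 `Cn1c(Cc2nn(C)c(=O)c3ccccc23)nnc1SCCCCCCCC(=O)Nc1ccc(Br)cc1Br` gives 1500 nM in this assay.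

Compound 3 has the lowest of the three numbers, but its neighbours are close: a 1.3-fold lower number from compound 2 to compound 3 (0.10 log units; within the scatter) and a 1.5-fold lower number from compound 1 to compound 3 (0.19 log units; within the scatter), so none of the three can be set apart. Compound 4 `Cn1c(Cc2nn(C)c(=O)c3ccccc23)nnc1SCCCCCCCC(=O)Nc1ccc(Cl)cc1` is not yet measured; it differs from compound 3 by 4-chlorophenyl in place of 2,4-dibromophenyl on an amide-type nitrogen. The measured steps only swap one pair of halogens for another: a 1.2-fold lower number from compound 1 to compound 2 (0.08 log units; within the scatter), a 1.5-fold lower number from compound 1 to compound 3 (0.19 log units; within the scatter), a 1.3-fold lower number from compound 2 to compound 3 (0.10 log units; within the scatter), all within the scatter. Going by the values given here, no step removes a halogen, so the move to compound 4 is less well covered. Compound 4 is therefore expected to sit near the others, with an expected step of a 1.3-fold higher number from compound 3 to compound 4 (0.12 log units; within the scatter) from compound 3. The estimate for compound 4 is 2000 nM, with a range of 1000 nM to 4500 nM.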

Compound 4, half-maximal inhibitory concentration: 800 nM
Beside the measured number, compound 4's estimate is 2.5-fold (0.40 log units) above it; the measured number lies below the stated range.
By their numbers in this assay, from the lowest: compounds 4, 3, 2 and 1 (each within the scatter of the next, the first and the last beyond it).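

At this amide-type nitrogen the swaps of one halogen pair for another had stayed within the scatter, and only here does a change of the halogen pattern produce steps beyond it: hydrogen in place of chloro on an aromatic carbon gives (a 2.4-fold lower number from compound 2 to compound 4 (0.38 log units; beyond the scatter)), and 4-chlorophenyl in place of 2,4-difluorophenyl gives (a 2.9-fold lower number from compound 1 to compound 4 (0.46 log units; beyond the scatter)). Replacing 2,4-dibromophenyl with 4-chlorophenyl remains within the scatter (a 1.9-fold lower number from compound 3 to compound 4 (0.27 log units; within the scatter)). Nothing available accounts for these steps.

The compounds shown leave open how plain phenyl, 4-fluorophenyl or 4-bromophenyl would read on this nitrogen. They also leave open whether a shorter chain would preserve these steps.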